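The source may hold more compounds than are shown below. What is called first, only, known or untested is meant among the compounds shown, and "the series" means these compounds.

In a functional assay on HL-60 cells (Homo sapiens) for cytotoxicity, read by WST assay, with a stated time of 48 h (on this read-out higher numbers stand for weaker inhibition and lower numbers for stronger inhibition), compound 1 (`COc1cc(C(c2ccc(O)c(OC)c2)[C@H](C)[C@H](C)CO)ccc1O`) gives > 100000 nM, which is a limit of the assay and not a number. For the measured compounds named here, compound 2 (`COc1cc(C(c2ccc(O)c(OC)c2)[C@@H](C)[C@@H](C)CF)ccc1O`) gives 38000 nM, so far the only actual number. Going by the values given here, the single measured step is an at least 2.6-fold lower number from compound 1 to compound 2 (0.42 log units; beyond the scatter), with 2-(fluoromethyl)-1-methylpropyl in place of 2-(hydroxymethyl)-1-methylpropyl. Compound 3 (`COc1cc(C(c2ccc(O)c(OC)c2)[C@H](CF)C(C)C)ccc1O`) has the same atoms as compound 2, joined differently: 1-(fluoromethyl)-2-methylpropyl in place of 2-(fluoromethyl)-1-methylpropyl on a saturated chain carbon bound to two aromatic carbons. The new change keeps the fluorine and rearranges the chain on the saturated chain carbon bound to two aromatic carbons. The step to compound 2, an at least 2.6-fold lower number from compound 1 to compound 2 (0.42 log units; beyond the scatter), exchanged a different group, so it gives no direct guide to the size or direction of this one. The estimated step is a 1.1-fold higher number from compound 2 to compound 3 (0.02 log units; within the scatter), and none beyond the scatter is expected. For compound 3 the expected value is 40000 nM, with an estimated range of 14000 nM to 100000 nM.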

Compound 3, half-maximal inhibitory concentration: 19000 nM
Estimate against measurement, compound 3: 2.1-fold (0.32 log units) above; the measured number falls inside the stated range.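

In this assay, rearranging the chain while keeping the fluorine gives a 2.0-fold lower number from compound 2 to compound 3 (0.30 log units; within the scatter), so at this position on a saturated chain carbon bound to two aromatic carbons, 1-(fluoromethyl)-2-methylpropyl and 2-(fluoromethyl)-1-methylpropyl cannot be told apart. The gain seen on leaving the 2-(hydroxymethyl)-1-methylpropyl chain therefore holds for a second fluorinated chain, with an at least 5.2-fold lower number from compound 1 to compound 3 (0.72 log units; beyond the scatter). Compound 1 remains a limit and not a number, so both steps from it give only a bound on their size: the limit of > 100000 nM in this assay, at which 1 of the 3 values shown sits.

The compounds shown leave open whether the same rearrangement of the chain would matter with a hydroxymethyl group in place of the fluoromethyl group. They also leave open how an amine, a carboxylic acid or a longer chain at this position would read out in this assay.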